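Thiophene to furan at the limit of the series

The compounds below may be only part of what the source reports. "The series", "measured", "known", "first", "only" and "open" are said of these compounds alone.

In a functional assay on HeLa cells (Homo sapiens) for cytotoxicity, read by CCK-8 assay (a higher number here means a weaker inhibitor, a lower number a stronger inhibitor), compound 1 (`Oc1cccc(-c2cc(-c3cccs3)cc(-c3ccccc3O)n2)c1`) gives > 50000 nM, a limit of the assay. Compound 2 (`Oc1ccc(-c2cc(-c3cccs3)cc(-c3ccccc3O)n2)cc1`) gives > 50000 nM, also a limit, so its place is known only as a bound. Compound 3 (`Oc1ccc(-c2cc(-c3cccs3)cc(-c3cccc(O)c3)n2)cc1`) reads 4140 nM. The measured steps are a step that the two limits leave unreadable from compound 1 to compound 2, an at least 12-fold lower number from compound 1 to compound 3 (1.08 log units; beyond the scatter) and an at least 12-fold lower number from compound 2 to compound 3 (1.08 log units; beyond the scatter). Compound 4 (`Oc1ccc(-c2cc(-c3ccco3)cc(-c3ccccc3O)n2)cc1`) differs from compound 2 by furan-2-yl in place of thiophen-2-yl on an aromatic carbon. None of these steps changes that group, so none sizes the swap directly. The large step, an at least 12-fold lower number from compound 2 to compound 3 (1.08 log units; beyond the scatter), replaces the 2-hydroxyphenyl group, which compound 4 keeps. No change beyond the scatter is therefore expected, and the expected step is a number no higher from compound 2 to compound 4 (the limit leaves the size open). For compound 4 the estimate is 50000 nM, with an expected range of 15000 nM to 100000 nM.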

Compound 4, half-maximal inhibitory concentration: > 50000 nM
Compound 4 ended at the assay's limit; the forecaster's own chance of this, stated with the estimate: 70%; the middle value sits exactly at the limit.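

No step can be read from compound 2 to compound 4, as both values are limits of the assay and not numbers. The compounds shown leave open what furan-2-yl in place of thiophen-2-yl does on a readable value.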